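Working notes: oral exposure from methoxy to chloro

The source may report more compounds than this note shows. Statements on the series, on what has been measured and on what is new or still open speak of the compounds shown alone.

compound 1 `COc1ccc(CNC(=O)c2c(C)nc3cc(C)ccn23)cc1` gives 18600 nM
compound 2 `COc1cccc(CNC(=O)c2c(C)nc3cc(C)ccn23)c1` gives 10100 nM

Both values come from an in vivo ADME assay on the whole organism (strain Sprague-Dawley) for pharmacokinetics, with Rattus norvegicus as the target, at a dose of 10 mg/kg by the oral route (a lower number here means less compound in the circulation, a higher number more compound in the circulation at the dose given), and compound 1 sits level with compound 2, since the gap between them lies within the usual scatter. The next compound is compound 3 `Cc1ccn2c(C(=O)NCc3ccc(Cl)cc3)c(C)nc2c1`, which has chloro in place of methoxy on an aromatic carbon, para to a large group (chloro in place of methoxy on an aromatic carbon). Within the data shown here, no measured pair shows this change, so there is no step to scale from. The expectation rests only on the level set by compound 1 at 18600 nM and compound 2 at 10100 nM in these notes. A step no larger than the scatter is expected, if anything towards a lower number. The estimated step is a 1.6-fold lower number from compound 1 to compound 3 (0.19 log units; within the scatter) on this basis. For compound 3 the estimate in this assay is 12000 nM with an expected range from 5000 nM to 28000 nM across repeat measurements.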

Compound 3, maximal plasma concentration in the Rattus norvegicus assay: 6360 nM
The estimate for compound 3 lay 1.9-fold (0.28 log units) above the measured number; the measured number falls inside the stated range.
By their numbers in the Rattus norvegicus assay, from the lowest: compounds 3, 2 and 1 (each within the scatter of the next, the first and the last beyond it).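

With chloro in place of methoxy on an aromatic carbon, para to a large group, the series shows its first listed step at this position, and it lies beyond the scatter: in the Rattus norvegicus assay the change gives a 2.9-fold lower number from compound 1 to compound 3 (0.47 log units; beyond the scatter). Oral exposure at this position therefore responds to the choice of group, and methoxy is the better of the two groups tested here. In a physicochemical assay for solubility, in phosphate buffer, at pH 7.4 (a higher number here means a more soluble compound, a lower number a less soluble compound), compound 1 gives 148000 nM and compound 3 gives 25000 nM. The same pair also loses solubility in the physicochemical assay, which may contribute to the lower maximal plasma concentration, although one pair cannot establish this as the cause: the measured solubility of compound 1, 148000 nM, and of compound 3, 25000 nM, a 5.9-fold lower number (0.77 log units; beyond the scatter)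

A single pair leaves open whether maximal plasma concentration and solubility generally move together in this series. An amine or a carboxylic acid at this same position would test that link.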